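Para substituent on the pyrazoline aryl ring: replacing trifluoromethyl

The compounds below may be only part of what the source reports. "The series", "measured", "known", "first", "only" and "open" are said of these compounds alone.

Working notes on a small set sharing one core. Compound 1 `c1ccc(C2=NN(c3ccc(-c4ccccc4)nn3)C(c3ccccc3)C2)cc1` carries a plain phenyl on the pyrazoline carbon; in a functional assay on A549 cells (Homo sapiens) for antiproliferative activity, read by MTT assay, with a stated time of 24 h (on this read-out lower numbers stand for stronger inhibition and higher numbers for weaker inhibition), compound 1 gives > 100000 nM, which is a limit of the assay, not a number (the limit of > 100000 nM in this assay, at which 1 of the 3 values shown sits). Compound 2 `Clc1ccc(C2CC(c3ccccc3)=NN2c2ccc(-c3ccccc3)nn2)cc1` adds a chloro and gives 100000 nM in this assay; the step of a number no higher from compound 1 to compound 2 (the limit leaves the size open) cannot be sized. Compound 3 `FC(F)(F)c1ccc(C2CC(c3ccccc3)=NN2c2ccc(-c3ccccc3)nn2)cc1` carries a trifluoromethyl and gives 9160 nM, the lowest of the two numbers shown. Both steps into compound 3 are large: an at least 10-fold lower number from compound 1 to compound 3 (1.03 log units; beyond the scatter) and an 11-fold lower number from compound 2 to compound 3 (1.04 log units; beyond the scatter).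

Compound 4 `COc1ccc(C2CC(c3ccccc3)=NN2c2ccc(-c3ccccc3)nn2)cc1` is not yet measured. Its change from compound 3: methoxy in place of trifluoromethyl on an aromatic carbon. Going by the values given here, no measured step covers methoxy; the only bearing steps are those into compound 3, where trifluoromethyl lowered the number well beyond the scatter from both hydrogen and chloro. Taking the trifluoromethyl away is therefore expected to move the number back up in this assay, and the expected step is a 6.6-fold higher number from compound 3 to compound 4 (0.82 log units; beyond the scatter). For compound 4 the estimate is 60000 nM, with a range of 15000 nM to 150000 nM.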

Compound 4, half-maximal inhibitory concentration: 91700 nM
For compound 4 the middle estimate is 1.5-fold (0.18 log units) below the measured one; low and high end bracket the measured number.
By their numbers in this assay, from the lowest: compound 3; then compounds 4 and 2 (each within the scatter of the next).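

In this assay, methoxy does not retain the lower number seen with trifluoromethyl at this position on the aryl ring: a 10-fold higher number from compound 3 to compound 4 (1.00 log units; beyond the scatter). Methoxy and chloro cannot be told apart here, a 1.1-fold lower number from compound 2 to compound 4 (0.04 log units; within the scatter), which leaves compound 3 as the only member whose steps to all the others are printed as beyond the scatter, so the series so far offers a single substituent that stands out, not a trend across substituents. The comparison with hydrogen reads an at least 1.0-fold lower number from compound 1 to compound 4 (0.03 log units; that floor lies within the scatter), and its starting value is a limit of the assay, not a number: the limit of > 100000 nM in this assay, at which 1 of the 4 values shown sits.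

With only hydrogen, chloro, methoxy and trifluoromethyl shown at this position, it remains open whether the lower number is specific to trifluoromethyl or is shared by groups such as a nitrile, a methylsulfonyl or a carboxylic acid. Also open, as far as these compounds go, is how an amine or a longer alkoxy chain would read here, and whether the trifluoromethyl step would hold on the other aryl rings of the shared core.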